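The compounds below may be only part of what the source reports. "The series", "measured", "known", "first", "only" and "open" are said of these compounds alone.

Compound 1 `N#Cc1c(N)nc(SCc2nc3ccccc3[nH]2)c(C#N)c1-c1ccc(OCC2CC2)cc1`: 1%
Compound 2 `CC(C)COc1ccc(-c2c(C#N)c(N)nc(SCC(N)=O)c2C#N)cc1`: 9%
Compound 3 `N#Cc1c(N)nc2sc(C(N)=O)c(N)c2c1-c1ccc(OCC2CC2)cc1`: 13%

Three compounds were measured in an assay on CHO cells for displacement of a labelled ligand from adenosine receptor A3 (Homo sapiens), read by scintillation counting, with a stated time of 120 min, tested at 1 uM; a lower number here means less inhibition, a higher number more inhibition at the concentration tested (going by the name of the read-out). Compound 1 gives 1%, the lowest of the three numbers; compound 2 lies within the scatter of it, while compound 3 sits beyond the scatter above it. None of these three differs from another in a single place, so no step can be read between them. Compound 4 `N#Cc1c(N)nc(SCc2cnc[nH]2)c(C#N)c1-c1ccc(OCC2CC2)cc1` differs from compound 1 in one place: 1H-imidazol-5-yl in place of 1H-benzimidazol-2-yl on a saturated chain carbon bound to a sulfur. Among the measured compounds shown here, with no step to lean on and all three measured numbers low, the step from compound 1 to compound 4 is expected to be small, a number 5 percentage points higher from compound 1 to compound 4 (within the scatter), in no direction beyond the scatter. Compound 4 is therefore estimated at 6%, with a range of -5% to 20%.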

Compound 4, a percentage reported as inhibition, at one concentration (the size of the read-out at that concentration, not a potency): 1%
The estimate for compound 4 lay 5 percentage points above the measured number; the measured number falls inside the stated range.
By their numbers in this assay, from the lowest: compounds 1, 4, 2 and 3 (each within the scatter of the next, the first and the last beyond it).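

In this assay, among the compounds shown here, 1H-imidazol-5-yl in place of 1H-benzimidazol-2-yl on a saturated chain carbon bound to a sulfur gives no change at the digits printed from compound 1 to compound 4 (within the scatter), the only step that can be read here. Losing the six-membered aromatic ring of carbon only, while keeping the five-membered aromatic ring with 2 hetero atoms, therefore leaves the read-out low at the concentration tested. Nothing available accounts for this result. As far as these compounds go, whether an amine, a carboxylic acid or a longer chain at this place would raise the inhibition remains open.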